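The source may hold more compounds than are shown below. What is called first, only, known or untested is meant among the compounds shown, and "the series" means these compounds.

Measured so far in an ADME assay on Huh-7 cells (Homo sapiens) for cytotoxicity, read by a luciferase reporter and WST assay, with a stated time of 3 days; on this read-out higher numbers stand for lower toxicity in this test and lower numbers for higher toxicity in this test:
compound 1 `O=C(Nc1ccc(Cl)cc1)c1c(NO)cc(-c2ccccc2)oc1=O` — > 20000 nM
compound 2 `Cc1ccc(NC(=O)c2c(NO)cc(-c3ccccc3)oc2=O)cc1` — > 20000 nM
compound 3 `COC(=O)CNC(=O)c1c(NO)cc(-c2ccc(Cl)cc2)oc1=O` — > 20000 nM

Each of these three values is a limit of this assay, not a number. Compound 1 reaches only a limit in this assay. Compound 2 likewise reaches only a limit. Compound 3 likewise reaches only a limit. From compound 1 to compound 2 the change is methyl in place of chloro on an aromatic carbon, and the step that the two limits leave unreadable from compound 1 to compound 2 cannot be read, because of the limit of > 20000 nM in this assay, at which 3 of the 3 values shown sit. The difference between the core of compound 1 and the core of compound 3 is not broken down here.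

Compound 4 `COC(=O)CNC(=O)c1c(NO)cc(-c2ccc(C)cc2)oc1=O` is not yet measured in this assay. It differs from compound 3 by methyl in place of chloro on an aromatic carbon, the same change as that from compound 1 to compound 2. Since that earlier step was left unreadable by the limits, the expected step that the limit leaves unreadable from compound 3 to compound 4 rests only on compound 3 sitting at > 20000 nM. Compound 4 is estimated at 40000 nM, between 15000 nM and 150000 nM, most likely again reported as a limit.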

Compound 4, half-maximal cytotoxic concentration: > 20000 nM
Compound 4: only a limit was reported; the forecaster's own chance of this, stated with the estimate: 85%; the middle value does not contradict the limit.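

Compound 4 gives > 20000 nM, a limit and not a number. No step can be read from compound 3 to compound 4 because both values are limits: the limit of > 20000 nM in this assay, at which 4 of the 4 values shown sit. The compounds shown leave open at what concentration any of them becomes cytotoxic, and whether methyl in place of chloro changes it.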